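The compounds below may be only part of what the source reports. "The series", "measured", "known", "first", "only" and "open" are said of these compounds alone.

Compound 1 `COc1ccc(-c2cc(=O)c3c(OC)cc(OC)cc3n2S(=O)(=O)c2ccc(C=O)cc2)cc1`: > 34400 nM
Compound 2 `COc1ccc(-c2cc(=O)c3c(OC)cc(OC)cc3n2S(=O)(=O)c2ccc([N+](=O)[O-])cc2)cc1`: 17300 nM
Compound 3 `COc1ccc(-c2cc(=O)c3c(OC)cc(OC)cc3n2S(=O)(=O)c2ccc(Cl)cc2)cc1`: > 34400 nM

In a functional assay on KOPN-8 cells (Homo sapiens) for antiproliferative activity, with a stated time of 72 h (on this read-out higher numbers stand for an effect only at larger amounts of compound and lower numbers for an effect already at smaller amounts), compound 3 gives only a limit, > 34400 nM, not a number. Compound 1 likewise gives only a limit, > 34400 nM. Among the compounds with values here, the one number, that of compound 2, leads to an at least 1.9-fold higher number from compound 2 to compound 3 (0.29 log units; that floor lies within the scatter), while a step that the two limits leave unreadable from compound 1 to compound 3 and an at least 1.9-fold lower number from compound 1 to compound 2 (0.29 log units; that floor lies within the scatter); two of the three values sit at the limit of > 34400 nM in this assay, at which 2 of the 3 values shown sit. Compound 4 `COc1ccc(-c2cc(=O)c3c(OC)cc(OC)cc3n2S(=O)(=O)c2cccc(Br)c2)cc1` differs from compound 3 by 3-bromophenyl in place of 4-chlorophenyl on a sulfonyl sulfur. Within the data shown here, none of the measured steps exchanges one halogen for another or shifts a group around the ring, so they give no direct guide; compound 3 stands at a limit, and compound 4 is expected to stay close to it, a step that the limit leaves unreadable from compound 3 to compound 4. For compound 4 the estimated value is 40000 nM, in a range from 15000 nM to 100000 nM.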

Compound 4, half-maximal effective concentration: > 58600 nM
Compound 4: only a limit was reported; the forecaster's own chance of this, stated with the estimate: 70%; at least 1.4-fold (0.16 log units) between middle value and limit.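

In this assay, within the data shown here, changing the group on the sulfonyl sulfur gives an at least 3.3-fold higher number from compound 2 to compound 4 (0.52 log units; beyond the scatter), the first step at this place printed as beyond the scatter. Compound 4 gives only a limit, not a number: the limit of > 58600 nM in this assay, at which 1 of the 4 values shown sits. The steps to compound 4 from compound 1 and from compound 3 cannot be read, with limits at both ends.

The shown compounds change halogen and ring place together, so the share of each stays open. Also open, as far as these compounds go, is what an amine or a carboxylic acid on this phenyl ring would give.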